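Adding a benzyl group to the amide of compound 2

The compounds below may be only part of what the source reports. "The series", "measured", "known", "first", "only" and "open" are said of these compounds alone.

Compound 1 `C=C[C@@](C)(/C=C/c1ccc(O)c(/C=C/C(=O)O)c1)CCC=C(C)C`: > 26000 nM (a limit)
Compound 2 `C=C[C@@](C)(/C=C/c1ccc(O)c(/C=C/C(N)=O)c1)CCC=C(C)C`: > 26000 nM (a limit)

In a functional assay on Raji cells (Homo sapiens) for cytotoxicity, with a stated time of 72 h (on this read-out higher numbers stand for an effect only at larger amounts of compound and lower numbers for an effect already at smaller amounts), compound 2 gives > 26000 nM, which is a limit and not a number. Both measured compounds stop at the same point: the limit of > 26000 nM in this assay, at which 2 of the 2 values shown sit. Compound 3 `C=C[C@@](C)(/C=C/c1ccc(O)c(/C=C/C(=O)NCc2ccc(C(F)(F)F)cc2)c1)CCC=C(C)C` keeps the shared core and changes only the amide: 4-(trifluoromethyl)benzyl in place of hydrogen on an amide-type nitrogen. The group that enters carries one six-membered aromatic ring of carbon only and no net charge. For the measured compounds named here, the one measured step, a step that the two limits leave unreadable from compound 1 to compound 2, also acted on the carbonyl carbon, yet it has no readable size to carry over. The data therefore fix no size for the new step, and the expectation in this assay is only a modest move towards lower numbers, or none beyond the scatter. The expected step is an at least 1.4-fold lower number from compound 2 to compound 3 (0.15 log units; that floor lies within the scatter). For compound 3 the estimate is 18000 nM, with an expected range from 5000 nM to 40000 nM.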

Compound 3, half-maximal effective concentration: > 26000 nM
Compound 3 ended at the assay's limit; the forecaster's own chance of this, stated with the estimate: 55%; at least 1.4-fold (0.15 log units) between middle value and limit.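

In this assay, for the compounds shown here, compound 3, like compound 2, gives only a limit and not a number, so no step between them can be read. All the compounds shown stop at the same point: the limit of > 26000 nM in this assay, at which 3 of the 3 values shown sit. On these data alone, whether any group on the amide nitrogen can bring a value short of that limit stays open.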